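From Acetamido to Acetamidomethyl: Compound 3 Awaits Measurement

A few compounds are considered here, and "the series" means these few. Any claim that something is new, unique, unknown or untested is made for them only; others in the source may bear on it.

Going by the values given here, only two compounds have been measured so far in a functional assay on HeLa cells (Homo sapiens) for cytotoxicity, read by resazurin assay, with a stated time of 72 h (a higher number here means a weaker inhibitor, a lower number a stronger inhibitor), and their values sit close together. Compound 1 `CCOC(=O)SCC(=O)c1ccc(OC)cc1` gives 18500 nM in this assay and compound 2 `CCSC(=S)SCC(=O)c1cccc(NC(C)=O)c1` gives 9380 nM there. These two values lie within the usual scatter of each other, so compound 2 cannot be ranked against compound 1.

Compound 3 `CCSC(=S)SCC(=O)c1cccc(CNC(C)=O)c1` keeps the core of compound 2 and alters one group, with acetamidomethyl in place of acetamido on an aromatic carbon. The counted difference acetamidomethyl in place of acetamido on an aromatic carbon is small, and the new group stays on the same aromatic carbon. Among the compounds with values here, no measured pair in this small set shows such a change, so any expectation is tentative. Within the data shown here, the only anchor for compound 3 is compound 2 at 9380 nM in this assay as its closest measured relative. The estimated step of a 1.1-fold higher number from compound 2 to compound 3 (0.03 log units; within the scatter) is expected to stay within the scatter, with no direction favoured. Compound 3 is expected at 10000 nM with 3500 nM to 28000 nM as the estimated range.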

Compound 3, half-maximal inhibitory concentration: 11300 nM
For compound 3 the middle estimate is 1.1-fold (0.05 log units) below the measured one, and the stated range covers the measured number.
By their numbers in this assay, from the lowest: compounds 2, 3 and 1 (each within the scatter of the next).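

Going by these compounds alone, compounds 2 and 3 form the only pair here that differs in one place, so they give the first direct reading of a change on this aromatic carbon. In this assay, putting acetamidomethyl in place of acetamido gives a 1.2-fold higher number from compound 2 to compound 3 (0.08 log units; within the scatter), which means that the two compounds cannot be ranked against each other. The entering group has 5 heavy atoms against 4 for the group it replaces, with the same count of hydrogen-bond donors and acceptors, and nothing available here bears on why the step takes this size.

Within the data shown here, this single step covers only two closely related amide groups at one place, so it leaves open whether an amine, a carboxylic acid or a longer chain on the same aromatic carbon would move the number in this assay beyond the scatter. Nor do the compounds shown say whether the same exchange of acetamido for acetamidomethyl would give a step of this size on a different core.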